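From propylcarbonyl to acetyl: compound 3 to compound 4

The source may hold more compounds than are shown below. What is called first, only, known or untested is meant among the compounds shown, and "the series" means these compounds.

Compound 1 `O=C(NCCCCCCSSCCCCCCNC(=O)c1cc(-c2ccncc2)n[nH]1)c1cc(-c2ccncc2)n[nH]1` 4740 nM
Compound 2 `C=CCOC(=O)SCCCCCCNC(=O)c1cc(-c2ccncc2)n[nH]1` 24800 nM
Compound 3 `CCCC(=O)SCCCCCCNC(=O)c1cc(-c2ccncc2)n[nH]1` 32100 nM

In a functional assay on PC-3 cells (Homo sapiens) for inhibition, read by MTT assay, with a stated time of 96 h (on this read-out lower numbers stand for stronger inhibition of growth and higher numbers for weaker inhibition of growth), compound 3 gives 32100 nM as its number, level with compound 2 within the scatter and clearly above compound 1. Compound 4 `CC(=O)SCCCCCCNC(=O)c1cc(-c2ccncc2)n[nH]1` differs from compound 3 in one place: hydrogen in place of ethyl on a saturated chain carbon bound to a carbonyl carbon with hydrogen in place of ethyl on a saturated chain carbon bound to a carbonyl carbon, so propyl becomes methyl. Among the compounds with values here, only one measured step bears on this, a 1.3-fold higher number from compound 2 to compound 3 (0.11 log units; within the scatter) where propyl replaced allyloxy on a carbonyl carbon. That step stayed within the scatter, so no clear shift in either direction is expected in this assay here. The expected size is a 1.2-fold lower number from compound 3 to compound 4 (0.09 log units; within the scatter) and no more. Compound 4 is estimated at 26000 nM with 11000 nM to 60000 nM as its expected range.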

Compound 4, concentration for 50% growth inhibition: 36000 nM
Beside the measured number, compound 4's estimate is 1.4-fold (0.14 log units) below it, and the stated range covers the measured number.
By their numbers in this assay, from the lowest: compound 1; then compounds 2, 3 and 4 (each within the scatter of the next).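

Cutting propylcarbonyl back to acetyl gives a 1.1-fold higher number from compound 3 to compound 4 (0.05 log units; within the scatter) in this assay and so shows that, over this span, shortening the chain leaves the number within the scatter. Swapping the allyloxy group for methyl on this carbonyl gives a 1.5-fold higher number from compound 2 to compound 4 (0.16 log units; within the scatter) and thus puts all three groups tried on this carbonyl level with one another. No measurement offers a reason for this flat result. Still open, going by these compounds, is whether a much longer chain, an amine or a carboxylic acid on a saturated chain carbon bound to a carbonyl carbon would move the number at all.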